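The source may report more compounds than this note shows. Statements on the series, on what has been measured and on what is new or still open speak of the compounds shown alone.

Measured compounds:

compound 1 `CCCCC(=O)NCCCO[C@@H]1[C@@H](C)N(C)C[C@H](C)C[C@@](C)(O)[C@H](O[C@@H]2O[C@H](C)C[C@H](N(C)C)[C@H]2O)[C@@H](C)[C@H](O[C@H]2C[C@@](C)(OC)[C@@H](O)[C@H](C)O2)[C@@H](C)C(=O)O[C@H](CC)[C@@]1(C)O` gives 3.74 in a physicochemical assay for lipophilicity, read by HPLC, measured as chromatographic lipophilicity, at pH 7.4; a lower number here means a more polar compound, a higher number a more lipophilic compound
compound 2 `CC[C@H]1OC(=O)[C@H](C)[C@@H](O[C@H]2C[C@@](C)(OC)[C@@H](O)[C@H](C)O2)[C@H](C)[C@@H](O[C@@H]2O[C@H](C)C[C@H](N(C)C)[C@H]2O)[C@](C)(O)C[C@@H](C)CN(C)[C@H](C)[C@@H](OCCCNC(C)=O)[C@]1(C)O` gives 2.41 in this assay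
compound 3 `CCCCC(=O)NCCCN(C)[C@H]1C[C@@H](C)O[C@@H](O[C@@H]2[C@@H](C)[C@H](O[C@H]3C[C@@](C)(OC)[C@@H](O)[C@H](C)O3)[C@@H](C)C(=O)O[C@H](CC)[C@@](C)(O)[C@H](O)[C@@H](C)N(C)C[C@H](C)C[C@@]2(C)O)[C@@H]1O` gives 3.08 in this assay

Compound 4 `CC[C@H]1OC(=O)[C@H](C)[C@@H](O[C@H]2C[C@@](C)(OC)[C@@H](O)[C@H](C)O2)[C@H](C)[C@@H](O[C@@H]2O[C@H](C)C[C@H](N(C)CCCNC(C)=O)[C@H]2O)[C@](C)(O)C[C@@H](C)CN(C)[C@H](C)[C@@H](O)[C@]1(C)O` is not yet measured. The change from compound 1 to compound 2 is hydrogen in place of propyl on a saturated chain carbon bound to a carbonyl carbon and it brought a number 1.33 log units lower from compound 1 to compound 2 (beyond the scatter). Within the data shown here, the change from compound 3 to compound 4 is hydrogen in place of propyl on a saturated chain carbon bound to a carbonyl carbon, the same change at the same kind of place, so the earlier step is the only guide. The difference between the core of compound 1 and the core of compound 3 is not broken down here; compound 3 sits between the other two in this assay. Among the measured compounds shown here, for compound 4 a step of a number 1.33 log units lower from compound 3 to compound 4 (beyond the scatter) is expected, resting on the single earlier step of a number 1.33 log units lower from compound 1 to compound 2 (beyond the scatter). The estimate for compound 4 in this assay is therefore 1.75, from 1.3 to 2.2.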

Compound 4, distribution coefficient: 2.06
The estimate for compound 4 lay 0.31 log units below the measured number; low and high end bracket the measured number.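

In this assay, hydrogen in place of propyl on a saturated chain carbon bound to a carbonyl carbon gives a number 1.02 log units lower from compound 3 to compound 4 (beyond the scatter), the same direction as a number 1.33 log units lower from compound 1 to compound 2 (beyond the scatter). The change therefore lowers the number on both cores shown, but two pairs do not establish a fixed step size or show that the direction holds on any other core. Nothing measured here accounts for the size of either step.

Still open, as far as these compounds go, is how this assay responds when the butylcarbonyl or acetyl group gives way to a longer chain. Also open, from the compounds shown here alone, is the response to an amine or a carboxylic acid at the end of the chain.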